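This account rests on a few compounds, and the source may have more. Where it says the series, first, only, none or still open, it means among the compounds named here.

In a functional assay on L1210 cells (Mus musculus) for cytotoxicity, with a stated time of 48 h (a lower number here means a stronger inhibitor, a higher number a weaker inhibitor), compound 1 `O=C1/C(=C/c2ccccc2)CCC/C1=C\c1cccc([N+](=O)[O-])c1` gives 9440 nM. Compound 2 `O=C1/C(=C/c2ccc(Cl)cc2)CCC/C1=C\c1ccc([N+](=O)[O-])cc1` gives 9410 nM in this assay, so the numbers of compound 1 and compound 2 lie within the usual scatter of each other, and compound 1 has the higher of the two numbers that were read as values. Compound 3 `CN(C)c1ccc(/C=C2\CCC/C(=C\c3ccc([N+](=O)[O-])cc3)C2=O)cc1` reaches only a limit of this assay, > 500000 nM, which is not a number (the limit of > 500000 nM in this assay, at which 1 of the 3 values shown sits). Compound 4 `COc1ccc(/C=C2\CCC/C(=C\c3cccc([N+](=O)[O-])c3)C2=O)cc1` has not yet been measured in this assay. It differs from compound 1 in one place: methoxy in place of hydrogen on an aromatic carbon. Among the compounds with values here, no measured step matches this change. Within the data shown here, the only step measured so far, an at least 53-fold higher number from compound 2 to compound 3 (1.72 log units; beyond the scatter), concerns a different pair of groups, so it offers no direct guide. Among the measured compounds shown here, with no matching step and a large rise seen for the one change that was measured, a modest rise in the number is expected for compound 4, a 2.1-fold higher number from compound 1 to compound 4 (0.33 log units; beyond the scatter). The estimate for compound 4 in this assay is 20000 nM, with a range from 6000 nM to 80000 nM.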

Compound 4, half-maximal inhibitory concentration: 29500 nM
The estimate for compound 4 lay 1.5-fold (0.17 log units) below the measured number; measured number inside the range.
By their numbers in this assay, from the lowest: compounds 2 and 1 (each within the scatter of the next); then compound 4. At a limit, above all of these: compound 3.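

Within the data shown here, the change from phenyl to 4-methoxyphenyl is the first measured change from hydrogen at this place, on an aromatic carbon para to a large group, and in this assay it gives a 3.1-fold higher number from compound 1 to compound 4 (0.49 log units; beyond the scatter). So adding a group here costs activity, though the step is only modest and compound 4 still gives a number that can be read. Among these compounds, compound 3, the only earlier compound changed at a comparable place, carries dimethylamino and stands at > 500000 nM, which is a limit and not a number.

Nothing measured here explains the rise in the number. On these data alone, it also remains open how a hydroxyl group, a primary amine or a carboxylic acid at this place would compare with methoxy and with hydrogen.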